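Lengthening the Ether Chain on the Shared Triazole Core

The source may report more compounds than this note shows. Statements on the series, on what has been measured and on what is new or still open speak of the compounds shown alone.

Compound 1 `CCc1nncn1-c1ccc(OCc2cccc(F)c2)cc1` and compound 2 `CCc1nncn1-c1ccc(OCc2cccc(Cl)c2)cc1` share their core with compound 3 `CCOc1ccc(-n2cnnc2CC)cc1`. In a functional assay on the whole organism (strain C57B/6) with Mus musculus as the target, in the maximal electroshock model (on this read-out lower numbers stand for an effect already at smaller amounts and higher numbers for an effect only at larger amounts of compound), compound 1 gives 22.8 mg/kg, while compound 2 gives 27.4 mg/kg, so that a 1.2-fold higher number from compound 1 to compound 2 (0.08 log units; within the scatter). Compound 3 reaches only a limit of the assay, > 100 mg/kg. For compound 3 nothing more is known than the limit of > 100 mg/kg in this assay, at which 1 of the 3 values shown sits. The steps of an at least 4.3-fold higher number from compound 1 to compound 3 (0.64 log units; beyond the scatter) and an at least 3.6-fold higher number from compound 2 to compound 3 (0.56 log units; beyond the scatter) show that shrinking the 3-fluorophenyl or 3-chlorophenyl group to methyl weakened the effect in both cases. Compound 4 `CCCCCCCOc1ccc(-n2cnnc2CC)cc1` differs from compound 3 by pentyl in place of hydrogen on a saturated chain carbon, two bonds along the chain from an oxygen on an aromatic ring, adding bulk where it was lost. Compound 4 is therefore expected to act at a smaller dose than compound 3, an estimated step of an at least 2.2-fold lower number from compound 3 to compound 4 (0.34 log units; beyond the scatter). The estimate for compound 4 is 45 mg/kg, with a range from 18 mg/kg to 110 mg/kg.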

Compound 4, dose for half-maximal effect: 8.3 mg/kg
Beside the measured number, compound 4's estimate is 5.4-fold (0.73 log units) above it; the whole stated range lies above it.
By their numbers in this assay, from the lowest: compound 4; then compounds 1 and 2 (each within the scatter of the next). At a limit, above all of these: compound 3.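

In this assay, pentyl in place of hydrogen at this position gives a large gain (an at least 12-fold lower number from compound 3 to compound 4 (1.08 log units; beyond the scatter)), which shows that the chain alone can lower the dose, with no aromatic ring on it. This open chain also beats both ring-bearing ethers (a 3.3-fold lower number from compound 2 to compound 4 (0.52 log units; beyond the scatter); a 2.7-fold lower number from compound 1 to compound 4 (0.44 log units; beyond the scatter)). Compound 3 stands at a limit, so the first step is only a minimum: (the limit of > 100 mg/kg in this assay, at which 1 of the 4 values shown sits).

As far as these compounds go, what a shorter chain such as butyl or a longer one such as decyl would give stays open. So does a chain carrying an amine.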